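The compounds below may be only part of what the source reports. "The series", "measured", "known", "first", "only" and "open" are said of these compounds alone.

In a physicochemical assay for lipophilicity, at pH 7.4 (a higher number here means a more lipophilic compound, a lower number a more polar compound), compound 1 `COc1ccc(Cl)cc1NC(=O)Cc1nn(CC(=O)O)c(=O)c2ccccc12` gives 1.9 and compound 2 `COc1cc(OC)c(NC(=O)Cc2nn(CC(=O)O)c(=O)c3ccccc23)cc1Cl` gives 1.64. These two differ in a single place, methoxy in place of hydrogen on an aromatic carbon, and that change amounts to a number 0.26 log units lower from compound 1 to compound 2 (within the scatter). Compound 3 `C[C@@H](C(=O)O)c1nn(Cc2cn3cc(OCC4CC4)c(Cl)cc3n2)c2ccccc2c1=O` stands at 2.41, the highest of the three numbers, and its gaps to both of the others lie beyond the usual scatter.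

Compound 4 `CCC(C(=O)O)c1nn(Cc2cn3cc(OCC4CC4)c(Cl)cc3n2)c2ccccc2c1=O` has not yet been measured. It differs from compound 3 in one place, with 1-carboxypropyl in place of 1-carboxyethyl on an aromatic carbon, next to the ring nitrogen: 1-carboxypropyl in place of 1-carboxyethyl on an aromatic carbon. Among the measured compounds shown here, the one measured step bears on this only loosely, since it concerns a different group on a different core. For the measured compounds named here, no measured pair shows this exact swap, so the forecast has no direct precedent. The natural starting point is compound 3 at 2.41, and the entering group is the larger of the two, so a modest rise is expected. The expected step in this assay is a number 0.39 log units higher from compound 3 to compound 4 (beyond the scatter), a tentative figure that may prove smaller. For compound 4 the estimated value is 2.8, with an expected range from 2.45 to 3.15.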

Compound 4, distribution coefficient: 2.71
Beside the measured number, compound 4's estimate is 0.09 log units above it; low and high end bracket the measured number.
By their numbers in this assay, from the lowest: compounds 2 and 1 (each within the scatter of the next); then compounds 3 and 4 (each within the scatter of the next).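

In this assay, among the compounds shown here, 1-carboxypropyl in place of 1-carboxyethyl on this aromatic carbon gives a number 0.30 log units higher from compound 3 to compound 4 (within the scatter), the first reading of any change at this position, since the only earlier step concerned a methoxy group on a different core. On this core, then, going from a group of 5 heavy atoms to one of 6, with the hydrogen-bond donor and acceptor counts unchanged, leaves the two compounds within the usual scatter of each other, so this pair alone does not establish a real difference. The swap also removes the defined stereocentre of the leaving group, and no measurement at hand explains the result or separates the contribution of the added carbon from that of the stereocentre.

A longer chain such as 1-carboxybutyl, or an amide or an amine at this position in place of the carboxylic acid, could show whether this carbon tolerates larger changes with as small a step. The same swap on another core would show whether the step holds beyond this one pair.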